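Notes on the ring methyl of compound 1

The source may report more compounds than this note shows. Statements on the series, on what has been measured and on what is new or still open speak of the compounds shown alone.

Measured so far in a functional assay on cells (Burkitts lymphoma cell, Homo sapiens) for antiproliferative activity, read by MTT assay; on this read-out lower numbers stand for stronger inhibition and higher numbers for weaker inhibition:
- compound 1 `C/C(=N\Nc1nc2ccccc2o1)c1cnc(C)cn1`: 150 nM
- compound 2 `CCC/C(=N\Nc1nc2ccccc2o1)c1ccccn1`: 6 nM
- compound 3 `C/C(=N\N(C)c1nc2ccccc2o1)c1ccccn1`: > 50000 nM (a limit)

Of the two numbers in this assay, compound 1 has the higher, 150 nM. Compound 2 gives 6 nM, lower by a margin beyond the scatter. Compound 3 gives > 50000 nM, which is a limit of the assay and not a number.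

The next compound for this assay is compound 4 `C/C(=N\Nc1nc2ccccc2o1)c1cnccn1`, which differs from compound 1 at a single place: hydrogen in place of methyl on an aromatic carbon. In words, hydrogen stands in place of methyl on an aromatic carbon. Among the compounds with values here, no measured pair isolates this change, so the expectation is only loosely anchored. It rests on compound 1 at 150 nM as the starting point. A modest move toward a lower number is expected in this assay, possibly not beyond the scatter. The expected change is a 1.7-fold lower number from compound 1 to compound 4 (0.22 log units; within the scatter). For compound 4 the estimated value is 90 nM, with an expected range of 25 nM to 350 nM.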

Compound 4, half-maximal inhibitory concentration: 280 nM
Compound 4: the middle estimate sits 3.1-fold (0.49 log units) below what was measured; the measured number falls inside the stated range.
By their numbers in this assay, from the lowest: compound 2; then compounds 1 and 4 (each within the scatter of the next). At a limit, above all of these: compound 3.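

Hydrogen in place of methyl on an aromatic carbon, para to a large group and next to the ring nitrogen, gives a 1.9-fold higher number from compound 1 to compound 4 (0.27 log units; within the scatter) in this assay. Within the data shown here, this is the first single-place change that can be read, and it shows that, for this pair, the ring methyl can be replaced by hydrogen with no change that stands clear of the scatter, so the methyl adds nothing measurable to the number for compound 1 on this read-out. No measurement at hand bears on the reason for this step.

Still open is whether a larger or different group on this same aromatic carbon, such as an amine, a carboxylic acid or a longer chain, would move the number beyond the scatter, as hydrogen and methyl are the only two substituents shown at this position. Also open, as far as these compounds go, is how much of the value of compound 2, 6 nM, comes from its chain and how much from its ring, as compound 2 differs from compound 4 in more than one place.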